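From 3-cyanopropyl to benzyl: an expected cytotoxicity step

The compounds below may be only part of what the source reports. "The series", "measured", "known", "first", "only" and "open" are said of these compounds alone.

Compound 1, `CCSC(=S)N1CCN(C(=S)SC(=S)N(C)C)CC1`, in an ADME assay on HeLa cells (Homo sapiens) for cytotoxicity, read by MTT assay, with a stated time of 24 h (a lower number here means a stronger inhibitor, a higher number a weaker inhibitor), gives 4480000 nM.
Compound 2, `CCCCSC(=S)N1CCN(C(=S)SC(=S)N(C)C)CC1`, in this assay gives > 5000000 nM, which is a limit of the assay.
Compound 3, `CN(C)C(=S)SC(=S)N1CCN(C(=S)SCCCC#N)CC1`, in this assay gives > 5000000 nM, also a limit.

Compound 3 therefore stands only as a limit, and (the limit of > 5000000 nM in this assay, at which 2 of the 3 values shown sit). The step to compound 4, `CN(C)C(=S)SC(=S)N1CCN(C(=S)SCc2ccccc2)CC1`, is phenyl in place of 2-cyanoethyl on a saturated chain carbon bound to a sulfur. For the measured compounds named here, the steps that bear on it are small and bounded: an at least 1.1-fold higher number from compound 1 to compound 2 (0.04 log units; that floor lies within the scatter), an at least 1.1-fold higher number from compound 1 to compound 3 (0.04 log units; that floor lies within the scatter), while a step that the two limits leave unreadable from compound 2 to compound 3. In this assay no step beyond the scatter is expected for compound 4, and a number no higher from compound 3 to compound 4 (the limit leaves the size open) is the estimated step. Compound 4 is expected to give 5000000 nM, in the range 2000000 nM to 15000000 nM.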

Compound 4, half-maximal inhibitory concentration: > 5000000 nM
Compound 4 was reported as a limit; the forecaster's own chance of this, stated with the estimate: 60%; the middle value sits exactly at the limit.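

In this assay, an aromatic ring now sits at this position, and the reading stays where the open chains of compound 2 and compound 3 left it, at the limit of the assay: the limit of > 5000000 nM in this assay, at which 3 of the 4 values shown sit.

For the compounds shown here, the one readable step is an at least 1.1-fold higher number from compound 1 to compound 4 (0.04 log units; that floor lies within the scatter); the other two new steps join two limits and cannot be read.

As far as these compounds go, whether an amine or a carboxylic acid at this position would give a readable number stays open, as does how far compound 2, compound 3 and compound 4 lie past their limits.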